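This account rests on a few compounds, and the source may have more. Where it says the series, first, only, none or still open, it means among the compounds named here.

Measured compounds in an ADME assay on Karpas-1106P cells (Homo sapiens) for cytotoxicity; on this read-out lower numbers stand for an effect already at smaller amounts and higher numbers for an effect only at larger amounts of compound:
- compound 1 `Cc1ccc(S(=O)(=O)N[C@@H](CC(=O)NC(C)(C)C)C(=O)NCCNC(=O)c2ccccc2)cc1`: compound 1 gives only a limit, > 11100 nM
- compound 2 `Cc1ccc(S(=O)(=O)N[C@@H](CC(=O)NC(C)(C)C)C(=O)NCCNC(=O)c2ccccc2Cl)cc1`: compound 2 gives only a limit, > 11100 nM
- compound 3 `Cc1ccc(S(=O)(=O)N[C@@H](CC(=O)NC(C)(C)C)C(=O)NCCNC(=O)c2ccc(Cl)cc2)cc1`: compound 3 gives only a limit, > 11100 nM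

Compound 1 stands at the limit of > 11100 nM in this assay, at which 3 of the 3 values shown sit; every value in this assay is a limit, none a number. The steps a step that the two limits leave unreadable from compound 1 to compound 2, a step that the two limits leave unreadable from compound 1 to compound 3 and a step that the two limits leave unreadable from compound 2 to compound 3 are therefore unreadable in size and direction.

Compound 4 `Cc1ccc(S(=O)(=O)N[C@@H](CC(=O)NC(C)(C)C)C(=O)NCCNC(=O)NCc2ccccc2)cc1` differs from compound 1 by benzylamino in place of phenyl on a carbonyl carbon. Going by the values given here, no measured step touches this part of the shared core, and the chloro steps give no readable size, so no direction can be drawn from them in this assay.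

Compound 4 is expected to remain at the limit as well, with an estimated value of 15000 nM (range 8000 nM to 40000 nM). The expected step is a step that the limit leaves unreadable from compound 1 to compound 4, nothing beyond the scatter.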

Compound 4, half-maximal effective concentration: > 11100 nM
Compound 4: a limit, no number (the forecaster's own chance of this, stated with the estimate: 80%); the middle value does not contradict the limit.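

Compound 4 gives only a limit in this assay, so its steps to compound 1, compound 2 and compound 3 cannot be read: the limit of > 11100 nM in this assay, at which 4 of the 4 values shown sit. The compounds shown leave open whether the chloro or benzylamino changes alter this read-out at all.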